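Fluoro to Hydrogen on the Pendant Phenyl of Compound 2

The source may hold more compounds than are shown below. What is called first, only, known or untested is meant among the compounds shown, and "the series" means these compounds.

The study measures antiproliferative activity in a functional assay on MCF7 cells (Homo sapiens) for antiproliferative activity, read by CellTiter-Glo, with a stated time of 5 days; on this read-out higher numbers stand for weaker inhibition and lower numbers for stronger inhibition. Compound 1 `CC1=C(c2cccc(O)c2)[C@H](c2ccc(OC[C@H](C)N3CC[C@@H](C)C3)cc2)Oc2ccc(O)cc21` gives 0.1 nM in this assay, and compound 3 `CC1=C(c2cccc(O)c2)C(c2ccc(OC[C@H](C)N3CC[C@@H](C)C3)cc2)Oc2cc(O)ccc21` gives 0.3 nM. Compound 2 `CC1=C(c2cccc(F)c2)C(c2ccc(OC[C@H](C)N3CC[C@@H](C)C3)cc2)Oc2ccc(O)cc21` gives 1 nM, the highest of the three numbers shown: compound 3 is nearest with a lower number beyond the scatter, and compound 1 is furthest, a lower number also beyond the scatter.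

The step from compound 2 leads to compound 4 `CC1=C(c2ccccc2)C(c2ccc(OC[C@H](C)N3CC[C@@H](C)C3)cc2)Oc2ccc(O)cc21`, in which (hydrogen in place of fluoro on an aromatic carbon). Going by the values given here, no measured pair in this set differs in the same way, so the size of this step is not known from the data. On the pattern of compounds 1 and 2, where the meta group changes from hydroxyl to fluoro and the number rises, the authors expect hydrogen at that place to leave the number near that of compound 2 or somewhat higher. The step from compound 2 to compound 4 is expected to be small, a 1.5-fold higher number from compound 2 to compound 4 (0.18 log units; within the scatter), toward weaker inhibition. Compound 4 is therefore expected to give 1.5 nM, within a range from 0.4 nM to 6 nM.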

Compound 4, half-maximal inhibitory concentration: 0.4 nM
For compound 4 the middle estimate is 3.8-fold (0.57 log units) above the measured one; the measured number falls inside the stated range.
By their numbers in this assay, from the lowest: compound 1; then compounds 3 and 4 (each within the scatter of the next); then compound 2.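

In this assay, going by these compounds alone, the change from 3-fluorophenyl to phenyl gives a 2.5-fold lower number from compound 2 to compound 4 (0.40 log units; beyond the scatter) and so supplies the only measured step at this place. It shows that the fluoro group is not required for a sub-nanomolar-range result on this aromatic carbon: with no heavy atom there at all, inhibition is stronger, not weaker or unchanged. Nothing available explains the direction of this step.

The compounds shown leave open whether other groups on this carbon, such as chloro, methoxy or an amine, would give numbers on the side of compound 4 or on the side of compound 2. They also leave open whether the same change from fluoro to hydrogen would give a step of similar size and direction on a different version of the shared core.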